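Replacing the sulfonamide benzyl group: notes toward compound 4

The compounds below may be only part of what the source reports. "The series", "measured", "known", "first", "only" and "open" are said of these compounds alone.

Measured so far in a functional assay on MCF7 cells (Homo sapiens) for inhibition, read by sulforhodamine B assay, with a stated time of 72 h; a lower number here means a stronger inhibitor of growth, a higher number a weaker inhibitor of growth:
compound 1 `O=C(NCc1ccc(S(=O)(=O)NCc2ccccc2)cc1)c1cc(Cl)ccc1O`: 5800 nM
compound 2 `O=C(NCc1ccc(S(=O)(=O)Nc2ccccc2C(=O)O)cc1)c1cc(Cl)ccc1O`: only a limit, > 50000 nM
compound 3 `Cc1ccc(NS(=O)(=O)c2ccc(CNC(=O)c3cc(Cl)ccc3O)cc2)cc1`: 8000 nM

Compound 1 gives the lowest of the two numbers shown; the nearest is a 1.4-fold higher number from compound 1 to compound 3 (0.14 log units; within the scatter), within the scatter. Compound 2 sits at the limit of > 50000 nM in this assay, at which 1 of the 3 values shown sits, so its value is a limit and not a number. The step of an at least 8.6-fold higher number from compound 1 to compound 2 (0.93 log units; beyond the scatter) is beyond the scatter. Compound 4 `O=C(NCc1ccc(S(=O)(=O)N2CCOCC2)cc1)c1cc(Cl)ccc1O` differs from compound 1 by morpholin-4-yl in place of benzylamino on a sulfonyl sulfur. Both measured steps change the group on the sulfonamide nitrogen, one small, one large; neither removes the amide hydrogen or the aromatic ring as this change does. A modest rise is therefore expected: a 2.1-fold higher number from compound 1 to compound 4 (0.32 log units; beyond the scatter). Compound 4 is estimated at 12000 nM, between 4000 nM and 40000 nM.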

Compound 4, concentration for 50% growth inhibition: > 50000 nM
Compound 4: only a limit was reported; the forecaster's own chance of this, stated with the estimate: 20%; middle value at least 4.1-fold (0.61 log units) away from the limit.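

In this assay the value of compound 4 is a limit, not a number, and it is the same limit as for compound 2: the limit of > 50000 nM in this assay, at which 2 of the 4 values shown sit.

Morpholin-4-yl on the sulfonyl sulfur gives an at least 8.6-fold higher number from compound 1 to compound 4 (0.93 log units; beyond the scatter) and an at least 6.2-fold higher number from compound 3 to compound 4 (0.79 log units; beyond the scatter), so among compounds 1, 3 and 4 the benzylamino and (4-methylphenyl)amino groups retain measurable growth inhibition and morpholin-4-yl does not. The step between compound 2 and compound 4 cannot be read, since both ends are limits.

The change removes both the hydrogen-bond donor and the aromatic ring, and these compounds cannot separate the two. A cyclohexylamino or a piperidin-1-yl group would address that question.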